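This account rests on a few compounds, and the source may have more. Where it says the series, first, only, none or still open, it means among the compounds named here.

Among the compounds with values here, in a functional assay (Cavia porcellus) with Rattus norvegicus as the target (on this read-out higher numbers stand for an effect only at larger amounts of compound and lower numbers for an effect already at smaller amounts), compound 1 `CCCCCCCCCO[C@@]1(c2ccc(Br)cc2)SC=C(C)n2c1noc2=O` gives 350 nM, the lower of the two numbers measured so far. Within the data shown here, compound 2 `CCCCCCCCCCCCCCCCCCO[C@@]1(c2ccc(Br)cc2)SC=C(C)n2c1noc2=O` gives 970 nM in this assay, and the single measured step, a 2.8-fold higher number from compound 1 to compound 2 (0.44 log units; beyond the scatter), corresponds to nonyl in place of hydrogen on a saturated chain carbon, nine bonds along the chain from an oxygen on a saturated carbon. Compound 3 `CC1=CS[C@@](OCC2CCCCC2)(c2ccc(Br)cc2)c2noc(=O)n21` differs from compound 1 by cyclohexyl in place of octyl on a saturated chain carbon bound to an oxygen on a saturated carbon. Among the measured compounds shown here, no measured step covers a shorter or ring-closed chain, and the one available step, a 2.8-fold higher number from compound 1 to compound 2 (0.44 log units; beyond the scatter), is modest, so the change in this assay is expected to stay within the scatter. Compound 3 is therefore estimated at 350 nM, with a range of 150 nM to 900 nM, which means a step of no change at the digits printed from compound 1 to compound 3 (within the scatter).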

Compound 3, half-maximal effective concentration: 190 nM
The estimate for compound 3 lay 1.8-fold (0.27 log units) above the measured number, within the range that was stated.
By their numbers in this assay, from the lowest: compounds 3 and 1 (each within the scatter of the next); then compound 2.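

Putting cyclohexyl in place of octyl on a saturated chain carbon bound to an oxygen on a saturated carbon gives a 1.8-fold lower number from compound 1 to compound 3 (0.27 log units; within the scatter) in this assay. This place therefore takes a ring of carbon only, read one bond further out as cyclohexylmethyl for nonyl, with no step beyond the scatter, whereas the longer chain gave a 2.8-fold higher number from compound 1 to compound 2 (0.44 log units; beyond the scatter). Nothing at hand gives a reason for this result. The compounds shown leave open how a shorter chain, a phenyl ring or an amine would read at this place.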